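A few compounds are considered here, and "the series" means these few. Any claim that something is new, unique, unknown or untested is made for them only; others in the source may bear on it.

Measured compounds in a functional assay on MCF7 cells (Homo sapiens) for antiproliferative activity, read by MTT assay, with a stated time of 48 h; on this read-out higher numbers stand for weaker inhibition and lower numbers for stronger inhibition:

compound 1, `N#CC1=C(N)Oc2c(N)cc3nc4ccccc4nc3c2C12C(=O)N(Cc1cnnn1-c1cccc(Br)c1)c1ccccc12`, gives only a limit of the assay, > 50000 nM.
compound 2, `N#CC1=C(N)Oc2c(N)cc3nc4ccccc4nc3c2C12C(=O)N(Cc1cnnn1-c1ccccc1Br)c1ccccc12`, gives 30700 nM.
compound 3, `N#CC1=C(N)Oc2c(N)cc3nc4ccccc4nc3c2C12C(=O)N(Cc1cnnn1-c1cccc(C(F)(F)F)c1)c1ccccc12`, gives 31600 nM.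

Compound 3 holds the highest of the two numbers shown; compound 2 is its nearest neighbour, and the gap, a 1.0-fold higher number from compound 2 to compound 3 (0.01 log units; within the scatter), lies within the scatter. The two steps that start from the limit, an at least 1.6-fold lower number from compound 1 to compound 2 (0.21 log units; that floor lies within the scatter) and an at least 1.5-fold lower number from compound 1 to compound 3 (0.19 log units; that floor lies within the scatter), have floors that also lie within the scatter, which rests on (the limit of > 50000 nM in this assay, at which 1 of the 3 values shown sits).

Compound 4, `COc1ccccc1-n1nncc1CN1C(=O)C2(C(C#N)=C(N)Oc3c(N)cc4nc5ccccc5nc4c32)c2ccccc21`, is the next compound in the series. Against compound 3 it differs in one place: 2-methoxyphenyl in place of 3-(trifluoromethyl)phenyl on an aromatic nitrogen. The steps measured so far all exchange the aryl group on the same triazole nitrogen, and none of them, an at least 1.6-fold lower number from compound 1 to compound 2 (0.21 log units; that floor lies within the scatter), an at least 1.5-fold lower number from compound 1 to compound 3 (0.19 log units; that floor lies within the scatter), a 1.0-fold higher number from compound 2 to compound 3 (0.01 log units; within the scatter), reaches beyond the scatter in this assay. On that basis the expected step of a 1.0-fold higher number from compound 3 to compound 4 (0.02 log units; within the scatter) is one of no change beyond the scatter. Compound 4 is therefore estimated at 33000 nM in this assay, within a range from 14000 nM to 80000 nM.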

Compound 4, half-maximal inhibitory concentration: 28900 nM
Beside the measured number, compound 4's estimate is 1.1-fold (0.06 log units) above it; measured number inside the range.
By their numbers in this assay, from the lowest: compounds 4, 2 and 3 (each within the scatter of the next). At a limit, above all of these: compound 1.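

In this assay, within the data shown here, 2-methoxyphenyl on the aromatic nitrogen brings in the first group of the series with a hydrogen-bond acceptor, yet the step stays within the scatter (a 1.1-fold lower number from compound 3 to compound 4 (0.04 log units; within the scatter)). Methoxy in place of bromo on the aromatic carbon likewise stays within the scatter (a 1.1-fold lower number from compound 2 to compound 4 (0.03 log units; within the scatter)), so among compound 2, compound 3 and compound 4 the exchange of these aryl groups separates nothing at this position. The remaining step (an at least 1.7-fold lower number from compound 1 to compound 4 (0.23 log units; that floor lies within the scatter)) gives only a floor, and that floor rests on a limit: (the limit of > 50000 nM in this assay, at which 1 of the 4 values shown sits).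

All aryl groups shown carry only bromo, trifluoromethyl or methoxy, so it stays open whether an amine or a carboxylic acid on the phenyl ring would move the number beyond the scatter. Also open, on these data alone, is whether a longer chain in place of the aryl group would do so.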